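The compounds below may be only part of what the source reports. "The series", "measured", "known", "first", "only" and "open" are said of these compounds alone.

In a functional assay on QGY-7703 cells (Homo sapiens) for cytotoxicity, read by MTT assay, with a stated time of 24 h (on this read-out higher numbers stand for weaker inhibition and lower numbers for stronger inhibition), compound 1 `N#Cc1ccc(S(=O)(=O)N2C/C(=C\c3ccncc3)C(=O)/C(=C/c3ccccc3F)C2)cc1` gives 8500 nM. Compound 2 `CC(=O)Nc1ccc(S(=O)(=O)N2C/C(=C\c3ccncc3)C(=O)/C(=C/c3ccccc3F)C2)cc1` differs from compound 1 in one place: acetamido in place of cyano on an aromatic carbon. In this assay compound 2 gives 13700 nM, and the step is a 1.6-fold higher number from compound 1 to compound 2 (0.21 log units; within the scatter). Compound 3 `N#Cc1ccc(S(=O)(=O)N2C/C(=C\c3cccnc3)C(=O)/C(=C/c3ccccc3C(F)(F)F)C2)cc1` carries a different core; how that core differs from the core of compound 1 is not broken down here. In this assay, going by the values given here, compound 3 gives 6150 nM, the lowest of the three numbers so far, although its gap to compound 1 lies within the scatter while its gap to compound 2 lies beyond it. Compound 4 `CC(=O)Nc1ccc(S(=O)(=O)N2C/C(=C\c3cccnc3)C(=O)/C(=C/c3ccccc3C(F)(F)F)C2)cc1` stands to compound 3 as compound 2 stands to compound 1: acetamido in place of cyano on an aromatic carbon. Among the compounds with values here, this is the same change at the same place, so the earlier step is the only guide to its effect. Because the earlier step was a 1.6-fold higher number from compound 1 to compound 2 (0.21 log units; within the scatter), compound 4 is expected to show a step of about a 1.5-fold higher number from compound 3 to compound 4 (0.19 log units; within the scatter). Compound 4 is therefore estimated to give around 9500 nM in this assay, with a band from 5500 nM to 17000 nM.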

Compound 4, half-maximal inhibitory concentration: 5380 nM
Compound 4: middle estimate off by 1.8-fold (0.25 log units), on the high side; measured number below the stated range.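

In this assay, the same change on the second core gives a 1.1-fold lower number from compound 3 to compound 4 (0.06 log units; within the scatter), so on this core too, acetamido in place of cyano leaves the number within the scatter. Set beside the step on the first core, the new step shows no difference that can be told from the scatter: the same change on two cores in this assay, a 1.6-fold higher number (0.21 log units; within the scatter) from compound 1 to compound 2 and a 1.1-fold lower number (0.06 log units; within the scatter) from compound 3 to compound 4, 1.8-fold (0.27 log units) apart, within the scatter of two such steps On these two cores, then, the change from 4-cyanophenyl to 4-acetamidophenyl carries across without a step that stands out, but this rests on only two pairs in one assay, and it neither establishes a real effect of the change in either direction nor shows that the same would hold on any other core.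

The compounds shown hold only cyano and acetamido on this aromatic carbon, so it stays open how an amine, a carboxylic acid or a longer amide chain would read in this assay. On these data alone, it also stays open whether the step would remain within the scatter on a third core.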